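A Single Double Bond Flipped from Z to E

A few compounds are considered here, and "the series" means these few. Any claim that something is new, unique, unknown or untested is made for them only; others in the source may bear on it.

Of the compounds shown here, two have been measured so far. Compound 1 `FC(F)(F)c1ccc(/C=C\c2cc3ccccc3nc2Cl)cc1` and compound 2 `Fc1ccc(/C=C\c2cc3ccccc3nc2Cl)cc1` share one core and differ in a single group. In a functional assay on HeLa cells (Homo sapiens) for antiproliferative activity, read by sulforhodamine B assay, with a stated time of 72 h (on this read-out higher numbers stand for weaker inhibition and lower numbers for stronger inhibition), compound 1 gives 4220 nM and compound 2 gives 24900 nM. For the measured compounds named here, the only measured step, a 5.9-fold higher number from compound 1 to compound 2 (0.77 log units; beyond the scatter), came from fluoro in place of trifluoromethyl on an aromatic carbon. On the two numbers shown, compound 2 stands highest, with compound 1 as its sole neighbour.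

Compound 3 `Fc1ccc(/C=C/c2cc3ccccc3nc2Cl)cc1` is the next case: the two compounds have the same atoms and bonds and differ only in configuration as drawn: 1 of 1 stereo elements differ; a double bond is drawn Z in compound 2 and E in compound 3. Going by the values given here, the one measured step concerns a substituent swap, so nothing measured here bears on a change of double bond geometry, and the expected size and direction of this step rest on the structural change alone, with wide uncertainty. The step from compound 2 to compound 3 is expected to be a 2.4-fold higher number from compound 2 to compound 3 (0.38 log units; beyond the scatter). Compound 3 is therefore expected to give about 60000 nM in this assay, with a likely range from 10000 nM to 300000 nM.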

Compound 3, half-maximal inhibitory concentration: > 50000 nM
Compound 3 was reported as a limit; the forecaster's own chance of this, stated with the estimate: 30%; the middle value lies beyond the limit too.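

In this assay compound 3 gives > 50000 nM, which is a limit of the assay and not a number. For the compounds shown here, this is the first look at the double bond itself, since the earlier step changed only a group on an aromatic carbon, and the new step reads an at least 2.0-fold higher number from compound 2 to compound 3 (0.30 log units; that floor lies within the scatter); that is a floor, so it does not show how far apart the two compounds really lie, and on its own it stays within the usual scatter. Any difference between them can be traced to the double bond alone, because nothing else changes: the fact that compounds 2 and 3 differ only in the configuration as drawn

On these data alone, whether the E geometry truly weakens inhibition therefore remains open, and so does the question of whether the trifluoromethyl compound, drawn Z as compound 1, would respond to the same flip as the fluoro compound does. Also open, as far as these compounds go, is how the Z series would respond if a methoxy group or an amine took the place of the fluoro on the aromatic ring, or if a nitrile took the place of the trifluoromethyl.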